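This account rests on a few compounds, and the source may have more. Where it says the series, first, only, none or still open, it means among the compounds named here.

In a functional assay on HepG2 cells (Homo sapiens) for cytotoxicity, read by MTT assay, with a stated time of 24 h (a lower number here means a stronger inhibitor, a higher number a weaker inhibitor), two compounds with a shared core have been measured. Compound 1 (`COc1cc(/C=C2\CN(S(=O)(=O)c3ccc(F)cc3)C/C(=C\c3cc(OC)c(OC)c(OC)c3)C2=O)cc(OC)c1OC`) gives 4200 nM, and compound 2 (`O=C1/C(=C/c2cccc([N+](=O)[O-])c2)CN(S(=O)(=O)c2ccc(F)cc2)C/C1=C\c1ccccc1F`) gives 7040 nM. These values lie within the scatter of each other, so compound 2 stands level with compound 1 on these numbers. Compound 3 (`COc1cc(/C=C2\CN(S(=O)(=O)c3ccc(F)cc3)C/C(=C\c3ccccc3F)C2=O)cc(OC)c1OC`) has 3,4,5-trimethoxyphenyl in place of 3-nitrophenyl on a double-bonded chain carbon bound to a double-bonded ring carbon. For the measured compounds named here, no measured pair isolates this change. Compound 1 also carries 3,4,5-trimethoxyphenyl and gives 4200 nM, so no step beyond the scatter is expected in this assay. The expected change is a 1.4-fold lower number from compound 2 to compound 3 (0.15 log units; within the scatter). The estimate for compound 3 is 5000 nM, with an expected range from 2000 nM to 12500 nM.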

Compound 3, half-maximal inhibitory concentration: 7940 nM
Estimate against measurement, compound 3: 1.6-fold (0.20 log units) below; the measured number falls inside the stated range.
By their numbers in this assay, from the lowest: compounds 1, 2 and 3 (each within the scatter of the next).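

In this assay, the exchange of 3-nitrophenyl for 3,4,5-trimethoxyphenyl on a double-bonded chain carbon bound to a double-bonded ring carbon can now be read directly, with 2-fluorophenyl held constant, and it gives a 1.1-fold higher number from compound 2 to compound 3 (0.05 log units; within the scatter). The exchange of 3,4,5-trimethoxyphenyl for 2-fluorophenyl at such a carbon gives a 1.9-fold higher number from compound 1 to compound 3 (0.28 log units; within the scatter), so neither single change separates its two compounds in this assay. Nothing available gives a reason for these results.

The three aryl groups shown thus leave open whether any group at this place can shift the number beyond the scatter, for example an amine or a carboxylic acid on the phenyl ring. Going by these compounds, it also remains open whether a group other than phenyl, such as a pyridine ring, would behave as these do.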